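Adding a Methoxy Group and Tolerance on Vero Cells

The source may report more compounds than this note shows. Statements on the series, on what has been measured and on what is new or still open speak of the compounds shown alone.

This piece follows one small structural step and asks what it means for how much compound the cells tolerate. The starting point is compound 1 `O=C(NCN1CCN(c2cc3c(cc2F)c(=O)c(C(=O)O)cn3C2CC2)CC1)c1cnccn1`. In a functional assay on Vero cells (Chlorocebus sabaeus) for cytotoxicity, read by MTT assay (a higher number here means that more compound is tolerated, a lower number that less compound is tolerated), compound 1 gives only a limit of the assay, > 62.5 ug/mL. Two companions are shown. Compound 3 `CCn1cc(C(=O)O)c(=O)c2cc(F)c(N3CCN(CNC(=O)c4cnccn4)CC3)c(F)c21` is also reported in this assay only as a limit, > 62.5 ug/mL. Compound 2 `COc1ccccc1N1CCN(CNC(=O)c2cnccn2)CC1` has no result in this assay, "not determined" (no result reported). The whole picture therefore rests on (the limit of > 62.5 ug/mL in this assay, at which 2 of the 3 values shown sit).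

The compound not yet measured is compound 4 `COc1c(N2CCN(CNC(=O)c3cnccn3)CC2)c(F)cc2c(=O)c(C(=O)O)cn(C3CC3)c12`. It differs from compound 1 in one place: methoxy in place of hydrogen on an aromatic carbon. Going by the values given here, no step between two measured compounds is available to calibrate such a change, so the expectation is a shift of none beyond the usual scatter in this assay, and most likely compound 4 will again be reported only as a limit. Compound 4 is thus estimated at 70 ug/mL, with an expected range from 30 ug/mL to 160 ug/mL. The step this estimate implies is expected to be a step that the limit leaves unreadable from compound 1 to compound 4.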

Compound 4, half-maximal cytotoxic concentration: > 62.5 ug/mL
Compound 4: no number, only a limit; the forecaster's own chance of this, stated with the estimate: 85%; the middle value is on the limit's open side.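

No step can be read from compound 1 to compound 4, since in this assay both are reported only as limits: the limit of > 62.5 ug/mL in this assay, at which 3 of the 4 values shown sit.

Going by these compounds, whether methoxy in place of hydrogen changes how much compound the cells tolerate stays open.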